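The source may hold more compounds than are shown below. What is called first, only, known or untested is meant among the compounds shown, and "the series" means these compounds.

Compound 1, whose structure is `COc1cc(-c2cc(/C=C/C(=O)c3ccc(N)cc3)[nH]n2)cc(OC)c1OC`, was examined in a functional assay on OVCAR-8 cells (Homo sapiens) for cytotoxicity, read by sulforhodamine B assay, with a stated time of 48 h, tested at 0.01 uM (on this read-out higher numbers stand for a weaker effect at the one concentration tested and lower numbers for a stronger effect), where compound 1 gives 100%. For the measured compounds named here, the only other measured compound, compound 2, with the structure `COc1ccc(-c2cc(/C=C/C(=O)c3ccc(OC)c(OC)c3)[nH]n2)cc1`, gives in this assay a read-out of 93%. The two numbers lie within the usual scatter of repeated measurements of each other, so the data do not separate compound 1 from compound 2; both sit at the top of the range the read-out can take, meaning neither shows a noticeable effect at the single concentration tested.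

Compound 3, with the structure `COc1cc(-c2cc(/C=C/C(=O)c3ccc(Cl)c(Cl)c3)[nH]n2)cc(OC)c1OC`, has not yet been measured in this assay. Compound 3 differs from compound 1 in one place: 3,4-dichlorophenyl in place of 4-aminophenyl on a carbonyl carbon. Going by the values given here, no step between two measured compounds is available that mirrors this change, so the expectation for compound 3 rests on what compound 1 and compound 2 show, namely that the read-out sits at the top of its range for both. The step from compound 1 to compound 3 in this assay is expected to be a number 3 percentage points lower from compound 1 to compound 3 (within the scatter), that is, none beyond the scatter. Compound 3 is therefore estimated to give about 97% in this assay, with a likely range from 82% to 105%.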

Compound 3, a percentage reported as activity, at one concentration (the size of the read-out at that concentration, not a potency): 94%
Compound 3: middle estimate off by 3 percentage points, on the high side; low and high end bracket the measured number.
By their numbers in this assay, from the lowest: compounds 2, 3 and 1 (each within the scatter of the next).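

For the compounds shown here, this is the first comparison in which only one place changes. In this assay, putting 3,4-dichlorophenyl in place of 4-aminophenyl on the carbonyl carbon gives a number 6 percentage points lower from compound 1 to compound 3 (within the scatter), so the read-out does not separate the two compounds. The exchange removes the hydrogen-bond donor and acceptor counted for 4-aminophenyl and brings in two chlorine atoms, yet compound 3 stays near the top of the range with compound 1, which means that this change produces no detectable effect at the single concentration tested. Nothing available explains this result.

On these data alone, whether a carboxylic acid, a pyridine ring or a morpholine in place of 3,4-dichlorophenyl on the carbonyl carbon would bring the read-out away from the top of its range remains open. Because compound 1 and compound 3 both lie so close to that top, the comparison also leaves open whether the two aryl groups would differ at any other concentration.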